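The source may report more compounds than this note shows. Statements on the series, on what has been measured and on what is new or still open speak of the compounds shown alone.

Values from a physicochemical assay for solubility, in phosphate buffer, measured as thermodynamic solubility, at pH 7.4; on this read-out lower numbers stand for lower solubility and higher numbers for higher solubility:
Compound 1 `CS(=O)(=O)NC(=O)CCc1cn(-c2ccc(Br)cc2)nc1-c1ccc(Cl)cc1`: 170000 nM
Compound 2 `CS(=O)(=O)NC(=O)CCc1cn(-c2ccc(Br)cc2)nc1-c1cccc(Cl)c1`: 165000 nM
Compound 3 `CNC(=O)CCc1cn(-c2ccc(Br)cc2)nc1-c1ccc(Cl)cc1`: < 5000 nM (a limit, not a number)

Compound 3 has no number of its own and sits at the limit of < 5000 nM in this assay, at which 1 of the 3 values shown sits. The next compound to consider is compound 4 `CS(=O)(=O)NCCCc1cn(-c2ccc(Br)cc2)nc1-c1ccc(Cl)cc1`. The change leading to it is (methanesulfonamido)methyl in place of methylcarbamoyl on a saturated chain carbon, two bonds along the chain from an aromatic carbon.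

Two measured steps are available. The first, a 1.0-fold lower number from compound 1 to compound 2 (0.01 log units; within the scatter), concerns the chlorophenyl group, which stays the same in this change, so it offers no guidance. Among the compounds with values here, the second, an at least 34-fold lower number from compound 1 to compound 3 (1.53 log units; beyond the scatter), is the only large step seen and also involves a methylsulfonyl group. That step, however, took place on an amide-type nitrogen, whereas the present change is on a saturated chain carbon, so it carries over only in part. Little movement is therefore expected in this assay, and a result at the same limit would not be surprising. The expected size is a step that the limit leaves unreadable from compound 3 to compound 4. For compound 4 the estimate is 4000 nM, with an expected range from 1500 nM to 15000 nM.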

Compound 4, solubility: < 5000 nM
Compound 4: only a limit was reported; the forecaster's own chance of this, stated with the estimate: 65%; the middle value lies beyond the limit too.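

In this assay compound 4 gives < 5000 nM, which is a limit and not a number. The methylsulfonyl group survives within the (methanesulfonamido)methyl group that enters on the saturated chain carbon, and still the result is an at least 34-fold lower number from compound 1 to compound 4 (1.53 log units; beyond the scatter), so a methylsulfonyl group alone does not go with the high number; among the compounds shown, only compound 1 and compound 2, which carry the intact (methylsulfonyl)carbamoyl group, give a number at all, and none goes against this. The step from compound 3 to compound 4 cannot be read, and the two compounds share one limit: the limit of < 5000 nM in this assay, at which 2 of the 4 values shown sit.

What the compounds shown leave open is how far compound 3 and compound 4 lie beyond their shared limit, and so whether these two differ at all. Also open, going by these compounds, is whether a carboxylic acid or a tetrazole in place of the (methylsulfonyl)carbamoyl group, or a longer chain carrying that group, would keep the number close to that of compound 1.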